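This account rests on a few compounds, and the source may have more. Where it says the series, first, only, none or still open, it means among the compounds named here.

Working notes on the series, read in a functional assay on RPMI-8226 cells (Homo sapiens) for inhibition, read by sulforhodamine B assay, with a stated time of 48 h; on this read-out lower numbers stand for higher toxicity in this test and higher numbers for lower toxicity in this test.

Compound 1 `O=C(Nc1cccc(-n2cc(-c3ccncc3)c(-c3ccc(Cl)c(O)c3)n2)c1)Nc1ccc(Cl)c(Cl)c1` gives in this assay > 32500 nM, which is a limit of the assay and not a number. Compound 2 `COc1cc(-c2nn(-c3cccc(NC(=O)Nc4ccc(Cl)c(C(F)(F)F)c4)c3)cc2-c2ccncc2)ccc1Cl` likewise gives > 32500 nM, again a limit. Compound 3 `COc1cc(-c2nn(-c3cccc(NC(=O)c4ccccc4)c3)cc2-c2ccncc2)ccc1Cl` gives > 100000 nM, also a limit. Compound 3 therefore stands at the limit of > 100000 nM in this assay, at which 1 of the 3 values shown sits, while the other two measured compounds sit at the limit of > 32500 nM in this assay, at which 2 of the 3 values shown sit. For the measured compounds named here, the only step between measured compounds that differ in one place, a step that the two limits leave unreadable from compound 2 to compound 3, lies between two limits, so its size and direction cannot be read.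

Compound 4 `COc1cc(-c2nn(-c3cccc(NC(=O)Nc4ccc(Cl)c(Cl)c4)c3)cc2-c2ccncc2)ccc1Cl` differs from compound 3 by (3,4-dichlorophenyl)amino in place of phenyl on a carbonyl carbon. Compound 1 and compound 2 both carry a substituted arylamino group on the carbonyl carbon, and both return only a limit, so nothing in the measured set points to a readable change for the step that this replacement makes. Compound 4 is expected to stay at a limit as well, with an estimated value of 60000 nM (range 25000 nM to 200000 nM), an expected step of an at least 1.6-fold lower number from compound 3 to compound 4 (0.22 log units; that floor lies within the scatter).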

Compound 4, concentration lethal to 50% of the cells: > 50000 nM
Compound 4: only a limit was reported; the forecaster's own chance of this, stated with the estimate: 85%; the middle value is on the limit's open side.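

Compound 4 also returns only a limit, so the steps linking it to compound 1, compound 2 and compound 3 cannot be read in size or direction. With all four values standing as limits, the compounds shown leave open whether any of these replacements shifts the read-out at all.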